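The compounds below may be only part of what the source reports. "The series", "measured", "known", "first", "only" and "open" are said of these compounds alone.

In a functional assay for antagonist activity at transient receptor potential cation channel subfamily V member 1 (Rattus norvegicus) (on this read-out higher numbers stand for weaker inhibition and lower numbers for stronger inhibition), compound 3 `CCCOc1cccnc1-c1ccc(C(=O)Nc2ccc(C(C)(C)C)cc2)cc1` gives 20 nM, the lowest of the three numbers measured here. Compound 2 `Cc1cccnc1-c1ccc(C(=O)Nc2ccc(C(F)(F)F)cc2)cc1` gives 81 nM, and compound 1 `Cc1cccnc1-c1ccc(C(=O)Nc2ccc(Cl)cc2)cc1` gives 2020 nM; the gap from compound 3 to compound 2 lies beyond the scatter, and so does the gap to compound 1. Going by the values given here, the only step between measured compounds that differ in one place is a 25-fold lower number from compound 1 to compound 2 (1.40 log units; beyond the scatter), and it concerns the aromatic ring on the amide nitrogen side. Compound 4 `CC(C)(C)c1ccc(NC(=O)c2ccc(-c3ncccc3N(S(C)(=O)=O)S(C)(=O)=O)cc2)cc1` differs from compound 3 by bis(methylsulfonyl)amino in place of propoxy on an aromatic carbon. That measured step does not bear on this change, so there is no precedent among these compounds for what such a replacement on the ring with one nitrogen does to the number. Among the compounds with values here, because compound 3 stands at 20 nM and the change has no comparable step here, the expected outcome is a 5.0-fold higher number from compound 3 to compound 4 (0.70 log units; beyond the scatter), toward a higher number, with wide uncertainty. Compound 4 is therefore estimated at 100 nM, with a range from 20 nM to 600 nM.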

Compound 4, half-maximal inhibitory concentration: 0.4 nM
Compound 4: the middle estimate sits 250-fold (2.40 log units) above what was measured; measured number below the stated range.
By their numbers in this assay, from the lowest: compound 4; then compound 3; then compound 2; then compound 1.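

Going by these compounds alone, on this ring with one nitrogen, at the carbon ortho to a large group and two atoms from the ring nitrogen, the number is far from fixed by propoxy: bis(methylsulfonyl)amino in its place gives a 50-fold lower number from compound 3 to compound 4 (1.70 log units; beyond the scatter) in this assay, the only measured step at this position. The entering group has more heavy atoms and hydrogen-bond acceptors than propoxy, has no hydrogen-bond donor, and is still compatible with a sub-nanomolar reading for compound 4 0.4 nM in this assay. Nothing measured here accounts for the size of this step.

The compounds shown leave open whether both methylsulfonyl groups are needed, since a single methylsulfonylamino group or a plain amine at this carbon would separate their contributions. They also leave open whether the step would persist with trifluoromethyl in place of tert-butyl on the other ring.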